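A few compounds are considered here, and "the series" means these few. Any claim that something is new, unique, unknown or untested is made for them only; others in the source may bear on it.

Measured in a functional assay on the whole organism for inhibition, with Lemna aequinoctialis as the target, tested at 100 ug/mL; a lower number here means less inhibition of growth, a higher number more inhibition of growth at the concentration tested:
Compound 1, `CCCCCCNC(=S)N/N=C1\C(=O)Nc2ccc([N+](=O)[O-])cc21`, gives 35%.
Compound 2, `Cc1cccc(NC(=S)N/N=C2\C(=O)Nc3ccc([N+](=O)[O-])cc32)c1`, gives 20%.

Compound 2 holds the lower of the two numbers in this assay; its nearest neighbour is compound 1, and the step of a number 15 percentage points lower from compound 1 to compound 2 (beyond the scatter) lies beyond the scatter. Among the measured compounds shown here, that step, 3-methylphenyl in place of hexyl on an amide-type nitrogen, is the only measured change in this small set.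

Compound 3, `Cc1ccc(NC(=S)N/N=C2\C(=O)Nc3ccc([N+](=O)[O-])cc32)cc1`, has not yet been measured in this assay. It differs from compound 2 in one place: 4-methylphenyl in place of 3-methylphenyl on an amide-type nitrogen. The two have the same atoms, joined differently. For the measured compounds named here, no measured step bears directly on a change of this kind: the one step known, a number 15 percentage points lower from compound 1 to compound 2 (beyond the scatter), exchanges a hexyl chain for an aromatic ring, whereas here one methylphenyl is exchanged for another. The step of a number 2 percentage points higher from compound 2 to compound 3 (within the scatter) is therefore expected to stay within the scatter, in no particular direction. Compound 3 is estimated to give 22% in this assay, with a range from 8% to 40%.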

Compound 3, percent growth inhibition at one concentration: 20%
Beside the measured number, compound 3's estimate is 2 percentage points above it; measured number inside the range.
By their numbers in this assay, from the lowest: compounds 2 and 3 (each within the scatter of the next); then compound 1.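

In this assay, 4-methylphenyl in place of 3-methylphenyl on the amide-type nitrogen gives no change at the digits printed from compound 2 to compound 3 (within the scatter), so the two methylphenyl groups cannot be told apart at this position, and this isomer pair shows no sensitivity to the change. The step from the hexyl compound is also now seen with a second aromatic group: a number 15 percentage points lower from compound 1 to compound 3 (beyond the scatter) matches a number 15 percentage points lower from compound 1 to compound 2 (beyond the scatter), so among these three compounds both methylphenyl compounds sit lower than the hexyl compound, and none of the three goes against this. Nothing available here accounts for the difference between hexyl and the methylphenyl groups, or for the absence of one between the two methylphenyl groups.

The compounds shown leave open whether the lower reading belongs to the aromatic ring itself or to the methylphenyl groups alone, which plain phenyl or a phenyl carrying a carboxylic acid or an amine on the same nitrogen could test in this assay. They also leave open whether a longer chain than hexyl, such as octyl, would give a number higher or lower than that of compound 1, which gives 35%.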